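The source may hold more compounds than are shown below. What is called first, only, known or untested is meant among the compounds shown, and "the series" means these compounds.

Measured so far:
compound 1, `COc1cc(CCc2ccc(F)cc2)cc(OC)c1O`, gives 1190 nM
compound 2, `COc1cc(CCc2cccc(Cl)c2Cl)cc(OC)c1O`, gives 8780 nM

In a functional assay on HCT-116 cells (Homo sapiens) for antiproliferative activity, read by MTT assay, with a stated time of 72 h (a higher number here means a weaker inhibitor, a lower number a stronger inhibitor), compound 2 stands at the higher of the two numbers, the weaker inhibitor; compound 1 sits well below it, a gap beyond the usual scatter. Compound 3, `COc1cc(CCc2ccccc2Cl)cc(OC)c1O`, is not yet measured. It differs from compound 2 by hydrogen in place of chloro on an aromatic carbon. Among the compounds with values here, no measured pair shows this change on its own, so its size is uncertain; a move toward a lower number is expected, of moderate size. Compound 3 is therefore estimated at 3500 nM, within 1200 nM to 10000 nM. The expected step is a 2.5-fold lower number from compound 2 to compound 3 (0.40 log units; beyond the scatter).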

Compound 3, half-maximal inhibitory concentration: 250 nM
The estimate for compound 3 lay 14-fold (1.15 log units) above the measured number; the measured number lies below the stated range.
By their numbers in this assay, from the lowest: compound 3; then compound 1; then compound 2.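

In this assay, within the data shown here, replacing one chloro group with hydrogen gives a 35-fold lower number from compound 2 to compound 3 (1.55 log units; beyond the scatter) and is the first single-place comparison in this set. It shows that this one aromatic carbon, ortho to the remaining chloro group, strongly affects antiproliferative activity, even though the change removes only one heavy atom. Nothing available explains why the step is so large. Still open, going by these compounds, is how an amine, a nitrile or a carboxylic acid would behave at this carbon. On these data alone, whether the same swap gives a similar step on other compounds also remains unknown.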